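The source may report more compounds than this note shows. Statements on the series, on what has been measured and on what is new or still open speak of the compounds shown alone.

Compound 1 `CCC(c1ccccc1)c1cc(O)nc(SC2CCCC2)n1` and compound 2 `CCC(c1ccccc1)c1cc(O)nc(SC2CCCCC2)n1` share one core and differ only in the group attached to the sulfur; compound 3 `CC(c1cc(O)nc(SC2CCCC2)n1)c1cccc2ccccc12` and compound 4 `CC(c1cc(O)nc(SC2CCCCC2)n1)c1cccc2ccccc12` form a second pair, built on a different core, that differ in exactly the same way. How the two cores differ is not broken down here.

In a functional assay on MT4 cells (Homo sapiens) for cytotoxicity (a higher number here means that more compound is tolerated, a lower number that less compound is tolerated), compound 1 gives 50000 nM, and compound 2 gives 51000 nM. The change between them is cyclohexyl in place of cyclopentyl on a sulfur and its measured step is a 1.0-fold higher number from compound 1 to compound 2 (0.01 log units; within the scatter), so the two numbers are indistinguishable. Compound 3 gives 93000 nM in this assay, a number that sits within the scatter of both compound 1 and compound 2.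

The change from compound 3 to compound 4 is cyclohexyl in place of cyclopentyl on a sulfur, the same change as between compound 1 and compound 2. Because the step of a 1.0-fold higher number from compound 1 to compound 2 (0.01 log units; within the scatter) left the number essentially unchanged, the step from compound 3 to compound 4 is expected to be about a 1.0-fold higher number from compound 3 to compound 4 (0.01 log units; within the scatter). Compound 4 is therefore estimated at 95000 nM in this assay, most likely between 45000 nM and 190000 nM.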

Compound 4, half-maximal cytotoxic concentration: 45000 nM
Compound 4: middle estimate off by 2.1-fold (0.32 log units), on the high side; the measured number falls inside the stated range.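

In this assay, putting cyclohexyl in place of cyclopentyl on the sulfur gives a 2.1-fold lower number from compound 3 to compound 4 (0.32 log units; beyond the scatter), a modest step that taken alone lies beyond the usual scatter, whereas the same swap on the core of compound 1 stayed within it. Set side by side, however, the two steps cannot be told apart: the same change on two cores in this assay, a 1.0-fold higher number (0.01 log units; within the scatter) from compound 1 to compound 2 and a 2.1-fold lower number (0.32 log units; beyond the scatter) from compound 3 to compound 4, 2.1-fold (0.32 log units) apart, within the scatter of two such steps. For the compounds shown here, the data therefore fit a single small effect of this swap on both cores; they do not show that the core changes the effect, and with only two pairs they do not prove that it carries over unchanged either.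

Still open, from the compounds shown here alone, is how other groups on the sulfur, such as a short ethyl chain or a benzyl group, would behave on these two cores. Going by these compounds, it is also open whether this swap would give a similar step on a third core, or in a read-out other than this assay.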